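Switching the drawn double-bond geometry in a piperidine oxime ether

The compounds below may be only part of what the source reports. "The series", "measured", "known", "first", "only" and "open" are said of these compounds alone.

Measured compounds:
compound 1, `CO/N=C(\CCN1CCN(c2ccccn2)CC1)c1ccc(Cl)cc1`, 37.6 nM
compound 2, `CO/N=C(\CCN1CCC(c2ccccn2)CC1)c1ccc(Cl)cc1`, 195 nM

Of the compounds shown here, two have been measured in a functional assay on HEK293 cells with D(4) dopamine receptor (Homo sapiens) as the target, read by FLIPR; a higher number here means that more compound is needed for the effect, a lower number that less compound is needed. Compound 1 gives 37.6 nM. Compound 2 gives 195 nM, the higher of the two numbers, and the gap to compound 1 lies beyond the scatter of repeated measurements. Within the data shown here, the two differ in the ring that carries the pyridine, but no single-change step between them has been worked out.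

Compound 3, `CO/N=C(/CCN1CCC(c2ccccn2)CC1)c1ccc(Cl)cc1`, has not yet been measured in this assay. It differs from compound 2 only in the geometry of the drawn double bond: the two compounds have the same atoms and bonds and differ only in configuration as drawn: 1 of 1 stereo elements differ; a double bond is drawn E in compound 2 and Z in compound 3.

Among the measured compounds shown here, no measured pair shows what such a change in drawn configuration does here, so the direction of the step is open. Compound 3 is therefore expected to land near compound 2, with a step of a 1.3-fold higher number from compound 2 to compound 3 (0.12 log units; within the scatter), and the estimate for compound 3 is 260 nM, within a range from 80 nM to 1200 nM.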

Compound 3, half-maximal effective concentration: > 10000 nM
Compound 3: a limit, no number; the forecaster's own chance of this, stated with the estimate: 5%; at least 38-fold (1.58 log units) between middle value and limit.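

Turning the drawn double bond from E to Z, with atoms and bonds unchanged, gives an at least 51-fold higher number from compound 2 to compound 3 (1.70 log units; beyond the scatter) in this assay. The earlier compounds differed in the ring that carries the pyridine and gave no view of this double bond, whereas this pair shows that its drawn configuration alone can carry a large step, one far beyond the scatter: the fact that compounds 2 and 3 differ only in the configuration as drawn The higher reading is a limit of the assay and not a number: the limit of > 10000 nM in this assay, at which 1 of the 3 values shown sits.

The compounds shown leave open whether the same switch would act alike on compound 1, as the only configuration pair here is the one in the piperidine oxime ether. They also leave open whether a longer chain, or a benzyl group in place of the methyl on the oxime oxygen, would depend on the drawn geometry to the same degree.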